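Thienyl-for-furyl acyl swap on the sulfonamide amide series

The source may report more compounds than this note shows. Statements on the series, on what has been measured and on what is new or still open speak of the compounds shown alone.

compound 1 `O=C(NCc1ccc(S(=O)(=O)N2CCCCC2)cc1)c1ccn2cncc2c1`: 1700 nM
compound 2 `O=C(NCc1ccc(S(=O)(=O)N2CCCCC2)cc1)c1cc2ccncc2o1`: 40 nM
compound 3 `O=C(NCc1ccc(S(=O)(=O)N2CCCCC2)cc1)c1cc2cnccc2o1`: 140 nM

In an assay for inhibition of Nicotinamide phosphoribosyltransferase (Homo sapiens), read by mass spectrometry, with stated times of 15 min and 30 min (a higher number here means a weaker inhibitor, a lower number a stronger inhibitor), compound 3 gives 140 nM, the second highest of the three numbers: its nearest neighbour is reached by a 3.5-fold higher number from compound 2 to compound 3 (0.54 log units; beyond the scatter), the furthest by a 12-fold lower number from compound 1 to compound 3 (1.08 log units; beyond the scatter). Compound 4 `O=C(NCc1ccc(S(=O)(=O)N2CCCCC2)cc1)c1cc2cccnc2s1` differs from compound 3 in one place: a group of 9 heavy atoms (7 carbon, 1 nitrogen, 1 sulfur; one five-membered aromatic ring with 1 hetero atom, one six-membered aromatic ring with 1 hetero atom) in place of a group of 9 heavy atoms (7 carbon, 1 nitrogen, 1 oxygen; one five-membered aromatic ring with 1 hetero atom, one six-membered aromatic ring with 1 hetero atom), on a carbonyl carbon. Every measured step alters the same bicyclic group on the carbonyl carbon. Those exchanging the five-membered ring were large, a 43-fold lower number from compound 1 to compound 2 (1.63 log units; beyond the scatter) and a 12-fold lower number from compound 1 to compound 3 (1.08 log units; beyond the scatter); the one that kept a five-membered ring with one hetero atom and rearranged only the six-membered ring, a 3.5-fold higher number from compound 2 to compound 3 (0.54 log units; beyond the scatter), was modest. Among the measured compounds shown here, an oxygen-to-sulfur exchange in the five-membered ring has no direct precedent here, so a modest step in either direction is expected. Compound 4 is estimated at 110 nM (range 30 nM to 400 nM), which is expected to mean a 1.3-fold lower number from compound 3 to compound 4 (0.10 log units; within the scatter).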

Compound 4, half-maximal inhibitory concentration: 8 nM
The estimate for compound 4 lay 14-fold (1.14 log units) above the measured number; the measured number lies below the stated range.
By their numbers in this assay, from the lowest: compound 4; then compound 2; then compound 3; then compound 1.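

Compound 4's sulfur-containing group on the carbonyl carbon gives the lowest number in the series, with an 18-fold lower number from compound 3 to compound 4 (1.24 log units; beyond the scatter), a 5.0-fold lower number from compound 2 to compound 4 (0.70 log units; beyond the scatter) and a 210-fold lower number from compound 1 to compound 4 (2.33 log units; beyond the scatter). The nitrogen of the six-membered ring also stands elsewhere in compound 4 than in compound 2 or compound 3, so the gain cannot be assigned to sulfur alone. No measurement here accounts for the gain.

Still open, as far as these compounds go, is how the oxygen counterpart with compound 4's nitrogen arrangement would compare. Also open, from the compounds shown here alone, is whether an amine or a carboxylic acid on this bicyclic group would be accepted.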